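Ring contraction in the amine side chain of compound 2

The source may report more compounds than this note shows. Statements on the series, on what has been measured and on what is new or still open speak of the compounds shown alone.

Compound 1 `CCN(CC)CCN(C)Cc1c(C(C)(C)C)nc2n(Cc3ccccc3F)c(C)c(-c3cccc(OC)c3)c(=O)n12` is the reference point in an assay on isolated protein for binding affinity to Gonadotropin-releasing hormone receptor (Homo sapiens) (on this read-out lower numbers stand for stronger inhibition and higher numbers for weaker inhibition), where compound 1 gives 260 nM. Compound 2 `COc1cccc(-c2c(C)n(Cc3ccccc3F)c3nc(C(C)(C)C)c(CNCC4CCCCC4)n3c2=O)c1` carries (cyclohexylmethyl)amino in place of the (2-(diethylamino)ethyl)(methyl)amino group on the saturated chain carbon bound to an aromatic carbon; in this assay compound 2 gives 430 nM. The step of a 1.7-fold higher number from compound 1 to compound 2 (0.22 log units; within the scatter) is the only measured one in the series. Among the two measured numbers compound 2 has the higher value, yet its gap to compound 1 stays within the scatter, so no order between them can be claimed.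

Compound 3 `COc1cccc(-c2c(C)n(Cc3ccccc3F)c3nc(C(C)(C)C)c(CNCC4CCCC4)n3c2=O)c1` differs from compound 2 by cyclopentyl in place of cyclohexyl on a saturated chain carbon bound to an amine nitrogen. Within the data shown here, no measured step touches this ring directly; the only comparison at hand, the exchange of the whole amine substituent from compound 1 to compound 2, stayed within the scatter. A change of one carbon in a saturated ring with no change in donors, acceptors or charge is therefore expected to produce no step beyond the scatter in this assay, with a 1.0-fold higher number from compound 2 to compound 3 (0.02 log units; within the scatter) as the expected outcome. For compound 3 the estimate in this assay is 450 nM, in the range 200 nM to 1000 nM.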

Compound 3, inhibition constant: 6400 nM
Compound 3: middle estimate off by 14-fold (1.15 log units), on the low side; the measured number lies above the stated range.
By their numbers in this assay, from the lowest: compounds 1 and 2 (each within the scatter of the next); then compound 3.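

In this assay, the ring on the saturated chain carbon bound to an amine nitrogen is not a silent detail: cyclopentyl in place of cyclohexyl gives a 15-fold higher number from compound 2 to compound 3 (1.17 log units; beyond the scatter), even though the counts of hydrogen-bond donors and acceptors and the net charge stay the same. The exchange of the whole amine substituent is also less permissive than the earlier pair suggested, since (cyclopentylmethyl)amino in place of (2-(diethylamino)ethyl)(methyl)amino gives a 25-fold higher number from compound 1 to compound 3 (1.39 log units; beyond the scatter), while the same exchange to (cyclohexylmethyl)amino gave a 1.7-fold higher number from compound 1 to compound 2 (0.22 log units; within the scatter), which lies within the scatter. No measurement at hand bears on why one ring carbon separates these results.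

The compounds shown leave open whether the six-membered ring marks a narrow preference or the start of a wider range, which a cycloheptyl or a phenyl group on the same chain carbon would test. Also open, going by these compounds, is whether a methyl on the amine nitrogen of the (cyclopentylmethyl)amino group would bring the number back towards those of the other two compounds.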